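Trimming one methoxy from a trimethoxy anabaseine analogue

This account rests on a few compounds, and the source may have more. Where it says the series, first, only, none or still open, it means among the compounds named here.

The series shares a core in which a pyridyl-substituted cyclic imine carries an arylidene group. Compound 1 `COc1cccc(/C=C2\CCCN=C2c2cccnc2)c1` bears a single methoxy on the aryl ring and in an assay on membranes from brain for displacement of a labelled ligand from Neuronal acetylcholine receptor; alpha4/beta2 (Rattus norvegicus), with a stated time of 3 h (a higher number here means a weaker inhibitor, a lower number a stronger inhibitor), compound 1 gives 1180 nM. Compound 3 `C(=C1\CCCN=C1c1cccnc1)\c1ccc(-n2ccnn2)cc1` carries a triazolyl group instead and in this assay compound 3 gives 520 nM. Compound 2 `COc1cc(OC)c(/C=C2\CCCN=C2c2cccnc2)c(OC)c1` has three methoxy groups and in this assay compound 2 gives 60 nM, the lowest of the three numbers, separated from compound 3 and compound 1 by gaps that lie beyond the scatter.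

Compound 4 `COc1ccc(/C=C2\CCCN=C2c2cccnc2)c(OC)c1` differs from compound 2 by one change: hydrogen in place of methoxy on an aromatic carbon. Among the measured compounds shown here, no measured pair shows exactly this change, so the size of the step is uncertain. Since compound 2 with three methoxy groups gives 60 nM while compound 1 with one gives 1180 nM, a modest weakening is expected, with a step from compound 2 to compound 4 of about a 3.3-fold higher number from compound 2 to compound 4 (0.52 log units; beyond the scatter). Compound 4 is therefore estimated at 200 nM, within a range from 60 nM to 700 nM.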

Compound 4, inhibition constant: 250 nM
Estimate against measurement, compound 4: 1.3-fold (0.10 log units) below; the range from low to high includes it.
By their numbers in this assay, from the lowest: compound 2; then compound 4; then compound 3; then compound 1.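

In this assay, among the compounds shown here, this is the first pair of compounds that differ in one place, and it puts a size on the change: hydrogen in place of methoxy, on an aromatic carbon ortho to a large group, gives a 4.2-fold higher number from compound 2 to compound 4 (0.62 log units; beyond the scatter) in a step that remains modest. This single methoxy therefore contributes to the low number of compound 2, but its loss alone leaves compound 4 only a modest step away. No measurement shown gives a reason for this step.

On these data alone, whether the step belongs to methoxy in particular stays open, and a hydroxyl, a fluorine atom or an ethoxy group on the same carbon would test that. For the compounds shown here, the separate contributions of the two methoxy groups that remain in compound 4 also stay open, with no pair here showing the removal of either.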